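This account rests on a few compounds, and the source may have more. Where it says the series, first, only, none or still open, it means among the compounds named here.

Compound 1 `COc1ccc(-c2cc(C)c(Oc3cc(N)nc(Nc4ccc(C#N)cc4)n3)c(C)c2)cc1`: 10700 nM
Compound 2 `Cc1cc(-c2ccccc2C#N)cc(C)c1Oc1cc(N)nc(Nc2ccc(C#N)cc2)n1`: 25400 nM

In a toxicity assay on MT4 cells (Homo sapiens) for cytotoxicity, read by MTT assay (on this read-out lower numbers stand for higher toxicity in this test and higher numbers for lower toxicity in this test), compound 2 holds the higher of the two numbers, at 25400 nM. Compound 3 `Cc1cc(-c2ccc(C#N)cc2)cc(C)c1Oc1cc(N)nc(Nc2ccc(C#N)cc2)n1` puts 4-cyanophenyl in place of 2-cyanophenyl on an aromatic carbon. Among the measured compounds shown here, only one measured step bears on this, and it is modest: a 2.4-fold higher number from compound 1 to compound 2 (0.38 log units; beyond the scatter). That step brought in 2-cyanophenyl in place of the 4-methoxyphenyl of compound 1, so a partial move back towards a lower number is expected, on thin evidence: a 1.6-fold lower number from compound 2 to compound 3 (0.20 log units; within the scatter). The estimate for compound 3 is 16000 nM, with an expected range of 5000 nM to 45000 nM.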

Compound 3, half-maximal cytotoxic concentration: 18100 nM
Compound 3: middle estimate off by 1.1-fold (0.05 log units), on the low side; the measured number falls inside the stated range.
By their numbers in this assay, from the lowest: compounds 1, 3 and 2 (each within the scatter of the next, the first and the last beyond it).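

In this assay, 4-cyanophenyl in place of 2-cyanophenyl gives a 1.4-fold lower number from compound 2 to compound 3 (0.15 log units; within the scatter) and so the nitrile can sit at either of these two places on the ring with no readable difference. Cyano in place of methoxy on that ring gives a 1.7-fold higher number from compound 1 to compound 3 (0.23 log units; within the scatter) as well, so only the 2-cyanophenyl of compound 2 stands clear of the 4-methoxyphenyl of compound 1. Nothing measured here explains these numbers. Going by these compounds, whether an amine or a carboxylic acid on this ring would move the number beyond the scatter stays open, as does the effect of a longer chain in place of the ring.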